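Estimating cytotoxicity for a larger fused group on the shared core

The source may hold more compounds than are shown below. What is called first, only, known or untested is meant among the compounds shown, and "the series" means these compounds.

Values in a toxicity assay on THP-1 cells (Homo sapiens) for cytotoxicity, read by luminescence and CellTiter-Glo, with a stated time of 72 h; a higher number here means that more compound is tolerated, a lower number that less compound is tolerated:
- Compound 1 `CN1CCN(c2ccc(Nc3nccc(-c4cccc(Cl)c4)n3)cc2C(F)(F)F)CC1`: 5280 nM
- Compound 2 `CN1CCN(c2ccc(Nc3nccc(-c4ccccc4)n3)cc2C(F)(F)F)CC1`: 4100 nM
- Compound 3 `CN1CCN(c2ccc(Nc3nccc(-c4cccnc4)n3)cc2C(F)(F)F)CC1`: 1060 nM

Among these three, compound 3 has the lowest number at 1060 nM, and its steps to both others lie beyond the scatter. Compound 4 `CN1CCN(c2ccc(Nc3nccc(-c4cnn5ncccc45)n3)cc2C(F)(F)F)CC1` keeps the shared core and changes one group, on an aromatic carbon: a group of 9 heavy atoms (6 carbon, 3 nitrogen; one five-membered aromatic ring with 2 hetero atoms, one six-membered aromatic ring with 2 hetero atoms) in place of a group of 6 heavy atoms (5 carbon, 1 nitrogen; one six-membered aromatic ring with 1 hetero atom), on an aromatic carbon.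

For the measured compounds named here, three measured steps bear on this site. Exchanging the chloro for hydrogen gave a 1.3-fold lower number from compound 1 to compound 2 (0.11 log units; within the scatter). Bringing in pyridin-3-yl gave modest changes, a 3.9-fold lower number from compound 2 to compound 3 (0.59 log units; beyond the scatter) and a 5.0-fold lower number from compound 1 to compound 3 (0.70 log units; beyond the scatter). Those two steps suggest that adding a ring nitrogen at this site can lower the number in this assay. However, no measured compound carries a group with two aromatic rings at this site, so the data say little about the new group itself. A step within the scatter is therefore expected, perhaps leaning slightly lower, and a modest step in either direction cannot be excluded. The estimated change is a 1.2-fold lower number from compound 3 to compound 4 (0.07 log units; within the scatter). For compound 4 the expected value is 900 nM, within an estimated range of 250 nM to 3500 nM.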

Compound 4, half-maximal cytotoxic concentration: < 50 nM
Compound 4 gave a limit, no number (the forecaster's own chance of this, stated with the estimate: 5%); middle value at least 18-fold (1.25 log units) from the limit.
By their numbers in this assay, from the lowest: compound 3; then compounds 2 and 1 (each within the scatter of the next). At a limit, below all of these: compound 4.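

Compound 4 gave a limit, not a number: the limit of < 50 nM in this assay, at which 1 of the 4 values shown sits.

At this position on the shared core, exchanges among groups with one aromatic ring had produced modest steps at most, whereas the group with a five-membered and a six-membered aromatic ring gave an at least 21-fold lower number from compound 3 to compound 4 (1.32 log units; beyond the scatter), along with an at least 82-fold lower number from compound 2 to compound 4 (1.91 log units; beyond the scatter) and an at least 100-fold lower number from compound 1 to compound 4 (2.02 log units; beyond the scatter). The site is therefore far more sensitive in this assay than the groups with one ring had shown, with all three steps large and each stated only as a minimum.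

The compounds shown do not separate the contribution of the second aromatic ring from that of the additional ring nitrogens, a question on which an all-carbon naphthalen-2-yl group or a lone pyrazole ring would bear. They also leave open how far the true value of compound 4 lies past its limit, and whether the sharp drop in tolerated concentration belongs to this one fused group or extends to other groups with two aromatic rings at this position.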